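The compounds below may be only part of what the source reports. "The series", "measured", "known", "first", "only" and "open" are said of these compounds alone.

Measured compounds:
Compound 1, `COc1cc2c(Oc3ccc(NC(=O)Nc4cccc(C)c4)cc3)ccnc2cc1OCCCCCCC(=O)NO`, gives 2010 nM in a functional assay on A549 cells (Homo sapiens) for antiproliferative activity, read by MTT assay; on this read-out lower numbers stand for stronger inhibition and higher numbers for weaker inhibition.
Compound 2, `COc1cc2c(Oc3ccc(NC(=O)Nc4ccccc4C(F)(F)F)cc3)ccnc2cc1OCCCCCCC(=O)NO`, gives 5280 nM in this assay.

Among the compounds with values here, of the two numbers known in this assay, compound 2 holds the highest; its nearest neighbour is compound 1, and the change a 2.6-fold higher number from compound 1 to compound 2 (0.42 log units; beyond the scatter) separates the two. The unmeasured compound 3, `COc1cc2c(Oc3ccc(NC(=O)N/N=C/c4ccccc4F)cc3)ccnc2cc1OCCCCCCC(=O)NO`, differs from compound 2 by a group of 9 heavy atoms (7 carbon, 1 nitrogen, 1 fluorine; one six-membered aromatic ring of carbon only) in place of a group of 10 heavy atoms (7 carbon, 3 fluorine; one six-membered aromatic ring of carbon only), on an amide-type nitrogen. Within the data shown here, the only step on record, from compound 1 to compound 2, also swaps the group on that same amide-type nitrogen and moved the number by a modest amount, so it shows that this position tolerates change without large shifts. Among the measured compounds shown here, no measured pair involves a group with a double bond outside aromatic rings at that site, so the direction of the coming step cannot be read from the data; the size, by analogy with the one known step, is expected to stay modest. Compound 3 is therefore expected to give about 4500 nM, somewhere between 1500 nM and 13000 nM, which means an expected change of a 1.2-fold lower number from compound 2 to compound 3 (0.07 log units; within the scatter).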

Compound 3, half-maximal inhibitory concentration: 7780 nM
For compound 3 the middle estimate is 1.7-fold (0.24 log units) below the measured one; the measured number falls inside the stated range.
By their numbers in this assay, from the lowest: compound 1; then compounds 2 and 3 (each within the scatter of the next).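

In this assay, within the data shown here, compound 3 shows that the group on the amide-type nitrogen can carry a double bond outside aromatic rings and a hydrogen-bond acceptor, features absent from that site in the earlier compounds, and that compound 2 and compound 3 cannot be told apart on this read-out (a 1.5-fold higher number from compound 2 to compound 3 (0.17 log units; within the scatter)). Compared with the 3-methylphenyl group, the new group gives a step beyond the scatter (a 3.9-fold higher number from compound 1 to compound 3 (0.59 log units; beyond the scatter)), so compound 1, which also stands clear of compound 2, holds the lowest number of the three. The three groups tried at this site therefore shift the number only modestly, and none brings compound 2 or compound 3 level with compound 1, although no other kind of measurement is available to account for these numbers.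

The compounds shown leave open which part of the new group matters, since a plain phenyl or a 2-chlorophenyl on the same linking unit would separate the ring fluorine from the rest of that group. They also leave open how a morpholine or a primary amine on that nitrogen would read in this assay, and whether a shorter chain bearing the hydroxamic acid or a carboxylic acid at the chain end would shift these numbers.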